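Moving one trifluoromethyl group in a sulfonamide series

The source may report more compounds than this note shows. Statements on the series, on what has been measured and on what is new or still open speak of the compounds shown alone.

Three related sulfonamides have numbers in an ADME assay on microsomes from liver (Rattus norvegicus, strain Sprague-Dawley) for metabolic stability, read by LC-MS, using NADPH, with a stated time of 30 min, tested at 3 uM; a lower number here means that less of the compound is left, a higher number that more of the compound is left. There, compound 3 (`CN1Cc2cc(-c3ccc(-c4cncc(NS(=O)(=O)c5cccc(C(F)(F)F)c5)c4)s3)cnc2C1=O`) gives 84%. Compound 2 (`COc1ncc(-c2ccc(-c3cnc4c(c3)CN(C)C4=O)s2)cc1NS(=O)(=O)c1ccccc1[N+](=O)[O-]`) gives 80%, within the usual scatter of compound 3, so the two cannot be told apart. Compound 1 (`CN1Cc2cc(-c3ccc(-c4cncc(NS(=O)(=O)c5ccc(F)cc5F)c4)s3)cnc2C1=O`) gives 100%, which is separated from compound 3 by more than the scatter.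

The next compound, compound 4 (`CN1Cc2cc(-c3ccc(-c4cncc(NS(=O)(=O)c5ccccc5C(F)(F)F)c4)s3)cnc2C1=O`), has 2-(trifluoromethyl)phenyl in place of 3-(trifluoromethyl)phenyl on a sulfonyl sulfur, and the rest of the structure is unchanged: 2-(trifluoromethyl)phenyl in place of 3-(trifluoromethyl)phenyl on a sulfonyl sulfur.

Going by the values given here, only one measured step touches this same place. Replacing 2,4-difluorophenyl with 3-(trifluoromethyl)phenyl gave a number 16 percentage points lower from compound 1 to compound 3 (beyond the scatter). That step is modest, but it exchanged one group for a different one, so it is only a rough guide. Among the compounds with values here, no measured pair shows what happens when the trifluoromethyl group alone changes its place on the phenyl ring. With so little evidence, no step beyond the scatter is expected in this assay. The expected change is a number 2 percentage points higher from compound 3 to compound 4 (within the scatter), a small shift that would stay within the scatter. For compound 4, the estimated value is 86%, with an expected range from 70% to 100%.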

Compound 4, percent of the compound remaining: 36%
Compound 4: the middle estimate sits 50 percentage points above what was measured, outside the stated range (below it).
By their numbers in this assay, from the lowest: compound 4; then compounds 2 and 3 (each within the scatter of the next); then compound 1.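

In this assay, going by these compounds alone, the place of the trifluoromethyl group on the phenyl ring turns out to matter a great deal: with the same atoms joined differently, 2-(trifluoromethyl)phenyl in place of 3-(trifluoromethyl)phenyl on the sulfonyl sulfur gives a number 48 percentage points lower from compound 3 to compound 4 (beyond the scatter), a large step that the earlier compounds gave no sign of. Within the data shown here, measured against 2,4-difluorophenyl on the same sulfonyl sulfur, the new group gives a number 64 percentage points lower from compound 1 to compound 4 (beyond the scatter), also large, whereas the only earlier step at this place was modest, so changes in this part of the molecule can shift the number much further than compounds 1 to 3 suggested. No measurement at hand explains why moving this one group changes how much of the compound is left.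

The compounds shown leave open how 4-(trifluoromethyl)phenyl on the same sulfonyl sulfur would compare with the two trifluoromethyl groups seen here. They also leave open whether the low number belongs to the trifluoromethyl group itself or would also appear with 2-chlorophenyl or 2-methoxyphenyl in its place.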